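The source may hold more compounds than are shown below. What is called first, only, known or untested is meant among the compounds shown, and "the series" means these compounds.

In a functional assay on L6 cells (Rattus norvegicus) for inhibition, read by scintillation counting, with a stated time of 3 h (a lower number here means a stronger inhibitor, a higher number a weaker inhibitor), compound 1 `COc1ccc(CNC(=O)c2nc(-c3ccc(F)cc3)n(CC[C@@H](O)C[C@@H](O)CC(=O)O)c2C2CC2)cc1` gives 6400 nM, compound 2 `COc1cccc(CNC(=O)c2nc(-c3ccc(F)cc3)n(CC[C@@H](O)C[C@@H](O)CC(=O)O)c2C2CC2)c1` gives 538 nM and compound 3 `Cc1cccc(CNC(=O)c2nc(-c3ccc(F)cc3)n(CC[C@@H](O)C[C@@H](O)CC(=O)O)c2C2CC2)c1` gives 532 nM. Compound 3 therefore sits level with compound 2 at the low end of these numbers, and both lie well under compound 1.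

The next structure, compound 4 `O=C(O)C[C@H](O)C[C@H](O)CCn1c(-c2ccc(F)cc2)nc(C(=O)NCc2ccccc2)c1C1CC1`, removes the ring substituent of compound 3: hydrogen in place of methyl on an aromatic carbon. In words, hydrogen takes the place of methyl on an aromatic carbon, meta to a large group.

Among the compounds with values here, three measured steps bear on this change. Exchanging methoxy for methyl on the ring gave a 1.0-fold lower number from compound 2 to compound 3 (0.00 log units; within the scatter), so the two groups cannot be told apart here. Compound 1 differs from compound 2 only in where the methoxy group sits on the ring, and that gave a 12-fold lower number from compound 1 to compound 2 (1.08 log units; beyond the scatter). Its comparison with compound 3 gave a matching a 12-fold lower number from compound 1 to compound 3 (1.08 log units; beyond the scatter). Among these three compounds, then, the large steps involve compound 1 alone.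

Within the data shown here, none of the measured compounds has an unsubstituted ring, so the removal of the group itself is untested. With the flat a 1.0-fold lower number from compound 2 to compound 3 (0.00 log units; within the scatter) as the closest guide, no step beyond the scatter is expected, with a slight rise in the number as the likelier direction. The expected step is a 1.3-fold higher number from compound 3 to compound 4 (0.12 log units; within the scatter). For compound 4 the estimated value is 700 nM, with an expected range from 250 nM to 2000 nM.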

Compound 4, half-maximal inhibitory concentration: 632 nM
Compound 4: the middle estimate sits 1.1-fold (0.04 log units) above what was measured; measured number inside the range.
By their numbers in this assay, from the lowest: compounds 3, 2 and 4 (each within the scatter of the next); then compound 1.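

Removing the methyl group outright gives a 1.2-fold higher number from compound 3 to compound 4 (0.07 log units; within the scatter) and removing the methoxy group gives a 1.2-fold higher number from compound 2 to compound 4 (0.07 log units; within the scatter) with the result that neither group is shown to offer anything over plain hydrogen at this place on the ring. Until now, methyl and methoxy could only be compared with each other, whereas the unsubstituted benzyl compound now supplies a baseline and shows that this position needs neither group to keep a number of this size. That baseline also sets compound 1 apart, since hydrogen in place of its methoxy group gives a 10-fold lower number from compound 1 to compound 4 (1.01 log units; beyond the scatter) and so the high number of compound 1 goes with a methoxy group placed as it is there, not with the lack of a group at the position studied here.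

Still open, as far as these compounds go, is whether a carboxylic acid, an amine or a longer chain at this place on the ring would leave the number just as flat, and whether a methyl group placed where compound 1 carries its methoxy group would raise the number in the same way. Nothing available explains why the methoxy group of compound 1 stands apart from the others.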